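The compounds below may be only part of what the source reports. "The series", "measured", "known", "first", "only" and "open" are said of these compounds alone.

In a functional assay on HCT-116 cells (Homo sapiens) for antiproliferative activity, read by MTT assay, with a stated time of 72 h (a higher number here means a weaker inhibitor, a lower number a stronger inhibitor), compound 1 `O=C(CCc1cccc2c1B(O)OC2)Nc1ccc(Br)cc1` gives 46000 nM, and compound 2 `O=C(CCc1cccc2c1B(O)OC2)Nc1cccc(Br)c1` gives 1400 nM. For the measured compounds named here, compound 2 therefore holds the lower of the two numbers measured so far. Going by the values given here, the only measured step, a 33-fold lower number from compound 1 to compound 2 (1.52 log units; beyond the scatter), is large and lies beyond the scatter. It bears on this question only indirectly, as it concerns where the bromo group sits and not which halogen is present. Compound 3 `O=C(CCc1cccc2c1B(O)OC2)Nc1cccc(I)c1` differs from compound 2 by iodo in place of bromo on an aromatic carbon, with iodo in place of bromo on an aromatic carbon, meta to a large group. Among the compounds with values here, no measured step exchanges one halogen for another, so the data give no direct size for this change. The place of the halogen is unchanged, and no step beyond the scatter is expected in this assay, in either direction. The estimated step is a 1.1-fold lower number from compound 2 to compound 3 (0.03 log units; within the scatter). For compound 3 the expected value is 1300 nM, with an estimated range from 450 nM to 3800 nM.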

Compound 3, half-maximal inhibitory concentration: 2300 nM
Estimate against measurement, compound 3: 1.8-fold (0.25 log units) below; the range from low to high includes it.
By their numbers in this assay, from the lowest: compounds 2 and 3 (each within the scatter of the next); then compound 1.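

In this assay, for the compounds shown here, the first exchange of one halogen for another at this place, iodo in place of bromo on an aromatic carbon, meta to a large group, gives a 1.6-fold higher number from compound 2 to compound 3 (0.22 log units; within the scatter), so the two halogens cannot be told apart here. The 3-iodophenyl group also stands clear of the 4-bromophenyl group, with a 20-fold lower number from compound 1 to compound 3 (1.30 log units; beyond the scatter), so the large gap first seen with the 3-bromophenyl group holds for a second halogen at this place. Nothing given here explains either step.

Going by these compounds, whether chloro, fluoro, an amine or a carboxylic acid at this place would keep the number in the same range stays open. On these data alone, it is also open whether a longer chain in place of the present one would shift it.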